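The compounds below may be only part of what the source reports. "The series", "measured", "known", "first", "only" and "open" are said of these compounds alone.

The series pairs two arrangements of the same atoms. Compound 1 `O=C(COc1ccc2c(=O)cc(-c3ccccc3)oc2c1)Nc1ccc(F)cc1` carries a 4-fluorophenyl amide and in a functional assay on MT2 cells (Homo sapiens) for antiproliferative activity, read by MTT assay, with a stated time of 72 h (a higher number here means a weaker inhibitor of growth, a lower number a stronger inhibitor of growth), compound 1 gives 6410 nM. Compound 2 `COc1ccc(NC(=O)COc2ccc3c(=O)cc(-c4ccccc4)oc3c2)cc1` differs from it only by methoxy in place of fluoro on an aromatic carbon, and in this assay compound 2 gives 6700 nM; the step of a 1.0-fold higher number from compound 1 to compound 2 (0.02 log units; within the scatter) shows that this swap left growth inhibition essentially unchanged. Compound 3 `O=C(COc1ccc2c(=O)c(-c3ccccc3)coc2c1)Nc1ccc(F)cc1` is built on a core that rearranges the same atoms of compound 1; how the two cores differ is not broken down here. In this assay compound 3 gives 2500 nM, the lowest number of the three measured compounds. Compound 4 `COc1ccc(NC(=O)COc2ccc3c(=O)c(-c4ccccc4)coc3c2)cc1` applies to compound 3 the same change, (methoxy in place of fluoro on an aromatic carbon), that turned compound 1 into compound 2, at the same place on the same kind of ring. For the measured compounds named here, since the one measured instance of this change was within the scatter, compound 4 is expected to sit close to compound 3, with an expected step of a 1.0-fold higher number from compound 3 to compound 4 (0.02 log units; within the scatter) in this assay. The estimate for compound 4 in this assay is therefore 2600 nM, expected to lie between 1300 nM and 5200 nM.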

Compound 4, concentration for 50% growth inhibition: 4550 nM
For compound 4 the middle estimate is 1.8-fold (0.24 log units) below the measured one; measured number inside the range.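

In this assay, placing methoxy where fluoro stood on the second core gives a 1.8-fold higher number from compound 3 to compound 4 (0.26 log units; within the scatter), so the swap leaves growth inhibition within the usual scatter here as well. Set beside the earlier step, the change carries from one core to the other with no difference that can be told from the scatter: the same change on two cores in this assay, a 1.0-fold higher number (0.02 log units; within the scatter) from compound 1 to compound 2 and a 1.8-fold higher number (0.26 log units; within the scatter) from compound 3 to compound 4, 1.7-fold (0.24 log units) apart, within the scatter of two such steps This shows only that one swap behaved alike on these two cores in one cell assay; it does not show that the same would hold on any other core, or for any other pair of groups.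

Going by these compounds, only fluoro and methoxy appear at this place on the amide's phenyl ring, so it remains open how a chlorine, a nitrile, an amine or a carboxylic acid there would read in this assay. The chain joining the core to the amide is also the same in all four compounds, which leaves open what a longer chain would do.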